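The source may report more compounds than this note shows. Statements on the series, on what has been measured and on what is new or still open speak of the compounds shown alone.

Measured in a functional assay on SW-620 cells (Homo sapiens); a higher number here means a weaker inhibitor of growth, a lower number a stronger inhibitor of growth:
- compound 1 `O=S(=O)(/C=C/c1ccc(F)cc1Cl)Cc1ccc(Nc2ncnc3ccccc23)cc1`: 100000 nM
- compound 2 `COc1cc2ncnc(Nc3ccc(CS(=O)(=O)/C=C/c4ccc(Cl)cc4Cl)cc3)c2cc1OC`: 2000 nM

Compound 2, at 2000 nM, holds the lower of the two numbers, and its gap to compound 1 lies beyond the scatter. Compound 3 `COc1cc2ncnc(Nc3ccc(CS(=O)(=O)/C=C/c4ccc(F)cc4)cc3)c2cc1OC` carries 4-fluorophenyl in place of 2,4-dichlorophenyl on a double-bonded chain carbon bound to a double-bonded chain carbon. Among the compounds with values here, no measured pair isolates this change, so only a small rise in the number is expected, possibly none beyond the scatter. The estimated step is a 1.5-fold higher number from compound 2 to compound 3 (0.18 log units; within the scatter). For compound 3 the expected value is 3000 nM, with an estimated range of 800 nM to 12000 nM.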

Compound 3, concentration for 50% growth inhibition: > 100000 nM
Compound 3: only a limit was reported; the forecaster's own chance of this, stated with the estimate: 5%; middle value at least 33-fold (1.52 log units) away from the limit.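

In this assay, the group on a double-bonded chain carbon bound to a double-bonded chain carbon proves decisive: 4-fluorophenyl in place of 2,4-dichlorophenyl gives an at least 50-fold higher number from compound 2 to compound 3 (1.69 log units; beyond the scatter). Compound 1 and compound 2 alone isolated no change at this position. Compound 3 gives only a limit and not a number: the limit of > 100000 nM in this assay, at which 1 of the 3 values shown sits.

The compounds shown do not separate the loss of one chlorine from the exchange of the other for fluorine. From the compounds shown here alone, how a phenyl ring carrying an amine or a carboxylic acid would read at this position also stays open.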